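Adding a fluoro to a compound at the limit

A few compounds are considered here, and "the series" means these few. Any claim that something is new, unique, unknown or untested is made for them only; others in the source may bear on it.

Compound 1 `O/N=C(\COc1cccc2ccccc12)c1ccc(F)cc1` has so far been tested only in an ADME assay on Jurkat cells (Homo sapiens) for cytotoxicity, read by MTT assay; a higher number here means a weaker inhibitor, a lower number a stronger inhibitor. In this assay compound 1 gives > 50000 nM, which is a limit and not a number. Compound 2 `O/N=C(\COc1cccc2ccccc12)c1ccc(C(F)(F)F)cc1` carries trifluoromethyl in place of fluoro on an aromatic carbon. In this assay compound 2 gives > 50000 nM, which is also a limit. Among the compounds with values here, the data therefore hold (the limit of > 50000 nM in this assay, at which 2 of the 2 values shown sit), and the only measured step is a step that the two limits leave unreadable from compound 1 to compound 2.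

Compound 3 `O/N=C(\COc1cccc2ccccc12)c1ccc(F)c(F)c1` is still unmeasured. It differs from compound 1 by fluoro in place of hydrogen on an aromatic carbon, ortho to a fluoro group and meta to a large group.

Within the data shown here, the one measured step gives no size to carry over, so it offers no ground for expecting a real change. With compound 2 in mind, the likeliest result is another limit, with no step beyond the scatter in this assay. The expected step is a step that the limit leaves unreadable from compound 1 to compound 3. For compound 3 the estimated value is 60000 nM, with an expected range from 30000 nM to 120000 nM.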

Compound 3, half-maximal inhibitory concentration: 42600 nM
Beside the measured number, compound 3's estimate is 1.4-fold (0.15 log units) above it, within the range that was stated.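

In this assay, within the data shown here, compound 3 gives 42600 nM, the only real number among the three compounds, so a fluoro ortho to a fluoro group and meta to a large group is compatible with a value that can be read. The change itself is an at least 1.1-fold lower number from compound 1 to compound 3 (0.06 log units; that floor lies within the scatter). This is only a floor, so the data do not establish that the added fluoro changes the result, and most of the values still give no size: the limit of > 50000 nM in this assay, at which 2 of the 3 values shown sit.

The step between compound 1 and compound 2 cannot be read, so the compounds shown give no measured size for swapping one group for another on this ring. Still open, as far as these compounds go, is whether an amine or a carboxylic acid at the new position, in place of the fluoro of compound 3, would give a number clearly different from that of compound 3 in this assay.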